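Amide-to-urea switch on the shared core: cytotoxicity notes

A few compounds are considered here, and "the series" means these few. Any claim that something is new, unique, unknown or untested is made for them only; others in the source may bear on it.

Compound 3 `COc1cccc(-n2nnc(-c3ccccc3NC(=O)c3ccc(NC(C)=O)cc3)n2)c1` stands only at a limit: in an ADME assay on NCI-H460 cells (Homo sapiens) for cytotoxicity, read by MTT assay, with a stated time of 72 h (a higher number here means a weaker inhibitor, a lower number a stronger inhibitor), compound 3 gives > 100000 nM, which is a limit of the assay and not a number. Compound 2 `COc1cccc(-n2nnc(-c3ccccc3NC(=O)c3ccc(N)cc3)n2)c1` gives > 100000 nM, likewise a limit. Compound 1 `COc1ccc(C(=O)Nc2ccccc2-c2nnn(-c3ccc(OC)cc3)n2)cc1` gives > 100000 nM, also a limit. Within the data shown here, the single measured step, a step that the two limits leave unreadable from compound 2 to compound 3, is therefore not readable, both of its ends sitting at the limit of > 100000 nM in this assay, at which 3 of the 3 values shown sit. Compound 4 `COc1cccc(-n2nnc(-c3ccccc3NC(=O)Nc3ccc([N+](=O)[O-])cc3)n2)c1` differs from compound 3 by (4-nitrophenyl)amino in place of 4-acetamidophenyl on a carbonyl carbon. Among the measured compounds shown here, no measured step bears on a change at the carbonyl carbon, so the size and direction of a number no higher from compound 3 to compound 4 (the limit leaves the size open) are expected to stay undetermined by the series so far. Compound 4 is expected to give 100000 nM, within 30000 nM to 300000 nM, most probably again reported only as a limit.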

Compound 4, half-maximal inhibitory concentration: > 100000 nM
Compound 4: only a limit was reported; the forecaster's own chance of this, stated with the estimate: 75%; the middle value sits exactly at the limit.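

Neither compound 2 nor compound 3 gives a readable step to compound 4, since every value stands at a limit: the limit of > 100000 nM in this assay, at which 4 of the 4 values shown sit.

The compounds shown leave open whether any change on the shared core shifts the result in this assay.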